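A few compounds are considered here, and "the series" means these few. Any claim that something is new, unique, unknown or untested is made for them only; others in the source may bear on it.

Measured so far in a physicochemical assay for lipophilicity, measured as octanol-water partition; a lower number here means a more polar compound, a higher number a more lipophilic compound:
- compound 1 `COc1cc(NC(C)CCCN2C(=O)CN(C(=O)[C@@H](C)N)C2(C)C)c2ncccc2c1` gives 2.49
- compound 2 `COc1cc(NC(C)CCCN2C(=O)CN(C(=O)CN)C2(C)C)c2ncccc2c1` gives 2.19
- compound 3 `COc1cc(NC(C)CCCN2C(=O)CN(C(=O)[C@H](N)C(C)C)C2(C)C)c2ncccc2c1` gives 2.93

Compound 3 stands highest of the three in this assay. Its nearest neighbour is compound 1, separated by a number 0.44 log units higher from compound 1 to compound 3 (beyond the scatter); its furthest is compound 2, separated by a number 0.74 log units higher from compound 2 to compound 3 (beyond the scatter). The remaining pair shows a number 0.30 log units lower from compound 1 to compound 2 (within the scatter), which does not rise above the scatter on its own.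

Compound 4 `CC[C@H](C)[C@@H](N)C(=O)N1CC(=O)N(CCCC(C)Nc2cc(OC)cc3cccnc23)C1(C)C` is the next member. Relative to compound 3 the change is methyl in place of hydrogen on a saturated chain carbon, three bonds along the chain from an amine nitrogen and a carbonyl carbon. The three measured steps all concern growth of the same side group on the same carbon chain and all point upward, the largest being the two-carbon addition from compound 2 to compound 3; the single-carbon additions are smaller. The present change adds one carbon one bond further out along that chain, so a step of roughly the size of the earlier single-carbon additions is expected, upward, in this assay: a number 0.37 log units higher from compound 3 to compound 4 (beyond the scatter).

Compound 4 is therefore estimated at 3.3 in this assay, with a range from 2.9 to 3.7.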

Compound 4, partition coefficient: 3.4
The estimate for compound 4 lay 0.10 log units below the measured number; the range from low to high includes it.
By their numbers in this assay, from the lowest: compounds 2 and 1 (each within the scatter of the next); then compound 3; then compound 4.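

In this assay, the upward run at this position does not stop at isopropyl: the change from isopropyl to sec-butyl gives a number 0.47 log units higher from compound 3 to compound 4 (beyond the scatter) and so adds a further step beyond the scatter from a single extra methyl, placed three bonds along the chain from an amine nitrogen and a carbonyl carbon. Across the whole side group, sec-butyl in place of hydrogen gives a number 1.21 log units higher from compound 2 to compound 4 (beyond the scatter), the only step in the set printed as large, while sec-butyl in place of methyl gives a number 0.91 log units higher from compound 1 to compound 4 (beyond the scatter), so the order from compound 2 and compound 1, which lie within the scatter of each other, through compound 3 to compound 4 holds with no compound against it. No supporting data bear on what lies behind the size of these steps.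

The compounds shown leave open whether the rise continues with a longer chain such as n-pentyl, or with a ring such as phenyl or cyclohexyl, on the same carbon. They also leave open how far a hydroxyl, an amine or a carboxylic acid on this side chain would move the number in this assay, and whether the other stereoisomers of the sec-butyl group give the same reading.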